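The source may report more compounds than this note shows. Statements on the series, on what has been measured and on what is new or still open speak of the compounds shown alone.

Of the compounds shown here, two sharing one core have been measured in a functional assay on HepG2 cells (Homo sapiens) for inhibition, read by MTT assay, with a stated time of 72 h; a higher number here means a weaker inhibitor, a lower number a stronger inhibitor. Compound 1 (`CC(C)(C)n1cc2c(n1)C(=O)CC1(CCN(C(=O)c3cc(-c4ccc(F)cc4)nc4ccccc34)CC1)O2`), which carries a 4-fluorophenyl group on an aromatic carbon, gives 2930 nM. Compound 2 (`Cc1cc(C(=O)N2CCC3(CC2)CC(=O)c2nn(C(C)(C)C)cc2O3)c2ccccc2n1`), with methyl in that place, gives 9480 nM, the higher of the two numbers, which makes it the weaker inhibitor of the pair. For the measured compounds named here, the only measured step, a 3.2-fold higher number from compound 1 to compound 2 (0.51 log units; beyond the scatter), is modest but beyond the scatter.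

Compound 3 (`CCOc1cc(C(=O)N2CCC3(CC2)CC(=O)c2nn(C(C)(C)C)cc2O3)c2ccccc2n1`) keeps the core of compound 2 and has ethoxy in place of methyl on an aromatic carbon, next to the ring nitrogen: ethoxy in place of methyl on an aromatic carbon. Going by the values given here, no measured step involves ethoxy, so the evidence is indirect. Among the compounds with values here, the sole guide is that compound 1, at 2930 nM, shows that a group other than methyl in this place can go with a lower number. That supports the direction only weakly, and a smaller change than the measured one is expected, possibly one that stays within the scatter. The expected change is a 1.6-fold lower number from compound 2 to compound 3 (0.20 log units; within the scatter). Compound 3 is therefore estimated at 6000 nM, with an expected range from 2500 nM to 14000 nM.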

Compound 3, half-maximal inhibitory concentration: > 10000 nM
Compound 3 gave a limit, no number; the forecaster's own chance of this, stated with the estimate: 5%; middle value at least 1.6-fold (0.22 log units) away from the limit.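

Compound 3 gives no number, only a limit of the assay: the limit of > 10000 nM in this assay, at which 1 of the 3 values shown sits. Ethoxy in place of methyl on this aromatic carbon, next to the ring nitrogen, gives an at least 1.0-fold higher number from compound 2 to compound 3 (0.02 log units; that floor lies within the scatter), so the distance between the two compounds remains unknown, but the limit offers no sign that ethoxy brings the lower number that compound 1 had suggested might come with a group other than methyl. Set against the 4-fluorophenyl group, ethoxy gives an at least 3.4-fold higher number from compound 1 to compound 3 (0.53 log units; beyond the scatter), which shows for the first time that replacing methyl at this place does not by itself go with a lower number, and that among the three groups shown the lower number belongs to compound 1 alone.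

The compounds shown leave open how far beyond the limit compound 3 lies, and so whether ethoxy differs from methyl in this assay at all. They also leave open whether an amine, a longer carbon chain or a phenyl ring without fluorine on this aromatic carbon would give a number closer to that of compound 1 or one closer to those of compound 2 and compound 3.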